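A few compounds are considered here, and "the series" means these few. Any claim that something is new, unique, unknown or untested is made for them only; others in the source may bear on it.

Working notes on the series. Compound 1 `COc1ccccc1OCC1N(C(=O)CC(=O)O)CC[S+]1[O-]` gives 20 mg/kg in a functional assay on the whole organism for inhibition, with Cavia porcellus as the target (a lower number here means that less compound is needed, a higher number that more compound is needed for the effect), and compound 2 `CCOC(=O)CC(=O)N1CC[S+]([O-])C1COc1ccccc1OC` gives 27 mg/kg in this assay. The change hydrogen in place of ethyl on an oxygen next to a carbonyl group gave a 1.4-fold lower number from compound 2 to compound 1 (0.13 log units; within the scatter). Compound 3 `CCOC(=O)C(C)(C)C(=O)N1CCSC1COc1ccccc1OC` gives 61 mg/kg in this assay, the highest number of the three; the difference between the core of compound 3 and the core of compound 2 is not broken down here. Compound 4 `COc1ccccc1OCC1SCCN1C(=O)C(C)(C)C(=O)O` repeats the same change on compound 3, as hydrogen in place of ethyl on an oxygen next to a carbonyl group, with the place worded identically; one bond further out it reads 1-(ethoxycarbonyl)-1-methylethyl to 1-carboxy-1-methylethyl rather than (ethoxycarbonyl)methyl to carboxymethyl. A step of a 1.4-fold lower number from compound 3 to compound 4 (0.13 log units; within the scatter) of about the same size is expected for compound 4, because a 1.4-fold lower number from compound 2 to compound 1 (0.13 log units; within the scatter) stayed within the scatter. Compound 4 is therefore expected at 45 mg/kg, between 20 mg/kg and 100 mg/kg.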

Compound 4, dose for half-maximal effect: 34 mg/kg
Estimate against measurement, compound 4: 1.3-fold (0.12 log units) above; low and high end bracket the measured number.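

In this assay, hydrogen in place of ethyl on an oxygen next to a carbonyl group gave a 1.8-fold lower number from compound 3 to compound 4 (0.25 log units; within the scatter), so on neither core does this change give a step beyond the scatter. The two steps agree as far as these pairs can tell, and the change carries from one core to the other without a detectable difference: the same change on two cores in this assay, a 1.4-fold lower number (0.13 log units; within the scatter) from compound 2 to compound 1 and a 1.8-fold lower number (0.25 log units; within the scatter) from compound 3 to compound 4, 1.3-fold (0.12 log units) apart, within the scatter of two such steps. This rests on two pairs whose steps both lie within the scatter, so it shows neither a real effect of the change on either core nor that the agreement would hold on a further core.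

The compounds shown leave open what a longer chain such as butyl would give on that oxygen, or an amide in place of ethoxycarbonyl. They also leave open how the two cores compare on their own, as no pair shown differs in the core alone.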